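Isobutyl in place of isopropyl: compound 3 to compound 4

The source may hold more compounds than are shown below. What is called first, only, known or untested is meant among the compounds shown, and "the series" means these compounds.

Measured compounds and values in a functional assay on MRC5 cells (Homo sapiens) for inhibition, read by microscopy and resazurin assay, with a stated time of 72 h; on this read-out higher numbers stand for weaker inhibition and lower numbers for stronger inhibition:
compound 1 `C=CCONC(=O)CN1C(=O)S/C(=C\c2cccc(C(=O)N[C@@H](CC(C)C)C(=O)OC)c2)C1=O`, reported only as a limit: > 128000 nM
compound 2 `C=CCONC(=O)Cn1ccc(C(=O)NCC(=O)N[C@@H](CC(C)C)C(=O)O)c1`, reported only as a limit: > 128000 nM
compound 3 `CC(C)[C@H](NC(=O)CNC(=O)c1ccn(CC(=O)NOCc2ccccc2)c1)C(=O)O`, reported only as a limit: > 128000 nM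

Compound 3 stands where every measured compound of this set stands: its value in this assay is a limit, not a number, and the limit of > 128000 nM in this assay, at which 3 of the 3 values shown sit, shows that all three values sit at the same limit. Within the data shown here, no measured pair is separated by any step, so no calibration for a structural change exists here.

Compound 4 `CC(C)C[C@H](NC(=O)CNC(=O)c1ccn(CC(=O)NOCc2ccccc2)c1)C(=O)O` carries isobutyl in place of isopropyl on a saturated chain carbon bound to an amide-type nitrogen and a carbonyl carbon. For this change the expectation is a step that the limit leaves unreadable from compound 3 to compound 4 of no size beyond the scatter. Compound 4 is therefore estimated at 160000 nM, with a range from 64000 nM to 500000 nM. It is expected that compound 4 is again reported only as a limit.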

Compound 4, half-maximal inhibitory concentration: > 128000 nM
Compound 4: no number, only a limit; the forecaster's own chance of this, stated with the estimate: 85%; the middle value does not contradict the limit.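

In this assay, among these compounds, compound 4 gives > 128000 nM, a limit, so no step to compound 4 from compound 3 or compound 2 can be read. The compounds shown leave open whether any structural change in the series yields a numerical value in this assay.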